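Imidazolylbutyl chain on the unsubstituted core

This account rests on a few compounds, and the source may have more. Where it says the series, first, only, none or still open, it means among the compounds named here.

In a functional assay on K562 cells (Homo sapiens) for antiproliferative activity, read by MTT assay, with a stated time of 48 h (a higher number here means a weaker inhibitor, a lower number a stronger inhibitor), compound 2 (`Cn1cc(C2=C(c3n[nH]c4ncccc34)C(=O)NC2=O)c2ccccc21`) stands at > 100000 nM, which is a limit of the assay and not a number. Compound 1 (`Cn1cc(C2=C(c3nn(CCCn4ccnc4)c4ncccc34)C(=O)NC2=O)c2ccccc21`), bearing 3-(1H-imidazol-1-yl)propyl, gives 13800 nM. Within the data shown here, the one measured step bearing on the change is an at least 7.2-fold higher number from compound 1 to compound 2 (0.86 log units; beyond the scatter), with hydrogen replacing that group, and it lies beyond the scatter. Compound 3 (`Cn1cc(C2=C(c3nn(CCCCn4ccnc4)c4ncccc34)C(=O)NC2=O)c2ccccc21`) carries 4-(1H-imidazol-1-yl)butyl in place of hydrogen on an aromatic nitrogen. A reversal of similar or greater size is expected in this assay, towards a lower number, with an estimated at least 8.3-fold lower number from compound 2 to compound 3 (0.92 log units; beyond the scatter). For compound 3 the expected value is 12000 nM, with an estimated range of 4000 nM to 40000 nM.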

Compound 3, half-maximal inhibitory concentration: 31800 nM
Estimate against measurement, compound 3: 2.7-fold (0.42 log units) below, within the range that was stated.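

In this assay, the gain from substitution on the aromatic nitrogen is not confined to a single chain length: an at least 3.1-fold lower number from compound 2 to compound 3 (0.49 log units; beyond the scatter). The value of compound 2 is a limit of the assay and not a number: the limit of > 100000 nM in this assay, at which 1 of the 3 values shown sits. Within the substituted pair, 4-(1H-imidazol-1-yl)butyl in place of 3-(1H-imidazol-1-yl)propyl gives a 2.3-fold higher number from compound 1 to compound 3 (0.36 log units; beyond the scatter), so the longer chain keeps only part of the gain.

Open, on these data alone, is whether the imidazole ring is needed at the chain end, as against an amine or a carboxylic acid. Also open, as far as these compounds go, is how a chain longer than butyl or shorter than propyl would read.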